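From 3,4-Difluorophenyl to 1H-Indazol-6-yl: an Expected Value

This account rests on a few compounds, and the source may have more. Where it says the series, first, only, none or still open, it means among the compounds named here.

Measured compounds:
compound 1, `O=C(Nc1ccc(-c2cscn2)cc1)C1CCCN(Cc2ccc(F)c(F)c2)C1`: 880 nM
compound 2, `O=C(Nc1ccc(-c2cscn2)cc1)C1CN(Cc2ccc(F)c(F)c2)C1`: a limit of the assay, > 20000 nM

Both were tested in a functional assay on A-375 cells (Homo sapiens) for antiproliferative activity; on this read-out higher numbers stand for weaker inhibition and lower numbers for stronger inhibition. Within the data shown here, compound 1 gives 880 nM and is the only compound with a number in this assay. Among the measured compounds shown here, compound 2 reached only a limit, (the limit of > 20000 nM in this assay, at which 1 of the 2 values shown sits), so no step between two measured compounds can be worked out, and the two values show only that compound 1 has a number where compound 2 has none.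

The next compound, compound 3, `O=C(Nc1ccc(-c2cscn2)cc1)C1CCCN(Cc2ccc3cn[nH]c3c2)C1`, keeps the whole of compound 1 except for one change: 1H-indazol-6-yl in place of 3,4-difluorophenyl on a saturated chain carbon bound to an amine nitrogen in a ring. The group that leaves carries no hydrogen-bond donor or acceptor; the group that enters carries one of each.

Without a measured step to lean on, the change is expected to move this assay by at most a modest amount in either direction, quite possibly within the scatter. Compound 3 is expected to give 1500 nM, in a range from 300 nM to 8000 nM. The step of a 1.7-fold higher number from compound 1 to compound 3 (0.23 log units; within the scatter) is therefore expected to be small.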

Compound 3, half-maximal inhibitory concentration: > 20000 nM
Compound 3 ended at the assay's limit; the forecaster's own chance of this, stated with the estimate: 10%; middle value at least 13-fold (1.12 log units) away from the limit.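

Among these compounds, this is the first step that can be read: in this assay, putting 1H-indazol-6-yl in place of 3,4-difluorophenyl gives an at least 22-fold higher number from compound 1 to compound 3 (1.35 log units; beyond the scatter). Compound 3 sits at a limit of the assay, > 20000 nM, which is not a number, so this step gives only the smallest size the change could have. It shows that this place, on a saturated chain carbon bound to an amine nitrogen in a ring, does not take every aromatic group equally, since this one change to compound 1 is enough to leave no measurable number, and only compound 1 now has one: the limit of > 20000 nM in this assay, at which 2 of the 3 values shown sit.

Among the compounds shown here, no step involving compound 2 can be read. The compounds shown also cannot separate the loss of the two fluorines from the arrival of the five-membered ring with its nitrogens, a question that plain phenyl, 4-fluorophenyl or 1-methyl-1H-indazol-6-yl at the same place could help to answer.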